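The source may hold more compounds than are shown below. What is called first, only, known or untested is meant among the compounds shown, and "the series" means these compounds.

Compound 2 `O=C(c1ccccc1)c1ccc(NC(=O)c2cc(Cl)ccc2O)cc1` was examined in a physicochemical assay for solubility, read by spectrophotometry; a lower number here means a less soluble compound, a higher number a more soluble compound. In this assay compound 2 gives < 50000 nM, which is a limit of the assay rather than a number. Compound 1 `O=C(Nc1ccc(C(F)(F)F)cc1)c1cc(Br)ccc1O` in this assay gives < 100000 nM, again only a limit. Compound 3 `O=C(c1ccccc1)c1ccc(NC(=O)c2cc(Br)ccc2O)cc1` has not yet been measured. It differs from compound 2 by bromo in place of chloro on an aromatic carbon. Among the measured compounds shown here, no step between measured compounds is available here, so the step expected from this change, a step that the limit leaves unreadable from compound 2 to compound 3, is small and likely not beyond the usual scatter. Compound 3 is therefore estimated at 30000 nM, with a range from 5000 nM to 60000 nM.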

Compound 3, solubility: < 50000 nM
Compound 3: only a limit was reported; the forecaster's own chance of this, stated with the estimate: 70%; the middle value does not contradict the limit.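

In this assay, the values of compound 1, compound 2 and compound 3 are all limits of the assay, so neither the step to compound 3 from compound 2 nor that from compound 1 can be read. The compounds shown leave open the actual solubility of all three and whether bromo in place of chloro changes it.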